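The compounds below may be only part of what the source reports. "The series", "measured", "known", "first", "only" and "open" are said of these compounds alone.

For the measured compounds named here, compound 1 `CCC1C(=O)N(C)c2cnc(Nc3ccc(S(N)(=O)=O)cc3)nc2N1C` gives 479 nM in an assay on Sf9 cells for inhibition of serine/threonine-protein kinase 4 (Homo sapiens), read by luminescence and ADP-Glo, with a stated time of 1 h, in the presence of a further agent that is not named here (a lower number here means a stronger inhibitor, a higher number a weaker inhibitor), the second highest of the three numbers so far. Compound 2 `COc1cccc(C2C(=O)N(C)c3cnc(Nc4ccc(S(N)(=O)=O)cc4)nc3N2C)c1` gives 954 nM in this assay, a change of a 2.0-fold higher number from compound 1 to compound 2 (0.30 log units; within the scatter). Compound 3 `CN1C(=O)C(c2ccccc2Cl)N(C)c2nc(Nc3ccc(S(N)(=O)=O)cc3)ncc21` gives 129 nM, the lowest of the three, with a 3.7-fold lower number from compound 1 to compound 3 (0.57 log units; beyond the scatter) and a 7.4-fold lower number from compound 2 to compound 3 (0.87 log units; beyond the scatter). Compound 4 `CN1C(=O)C(c2ccccc2Br)N(C)c2nc(Nc3ccc(S(N)(=O)=O)cc3)ncc21` has not been measured; relative to compound 1 the change is 2-bromophenyl in place of ethyl on a saturated ring carbon. The step from compound 1 to compound 3 bears most directly on it, since 2-bromophenyl and 2-chlorophenyl enter the same place; a drop of similar size is therefore expected for compound 4, of about a 3.2-fold lower number from compound 1 to compound 4 (0.50 log units; beyond the scatter). Compound 4 is thus estimated at 150 nM, within a range from 60 nM to 400 nM.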

Compound 4, half-maximal inhibitory concentration: 57 nM
Compound 4: middle estimate off by 2.6-fold (0.42 log units), on the high side, outside the stated range (below it).
By their numbers in this assay, from the lowest: compound 4; then compound 3; then compounds 1 and 2 (each within the scatter of the next).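

The step from chloro to bromo shows that the halogen itself counts at this saturated ring carbon, not only the presence of a 2-halophenyl group, with a 2.3-fold lower number from compound 3 to compound 4 (0.35 log units; beyond the scatter). The 2-bromophenyl group widens the gain over ethyl, with an 8.4-fold lower number from compound 1 to compound 4 (0.92 log units; beyond the scatter), and the gap to 3-methoxyphenyl, with a 17-fold lower number from compound 2 to compound 4 (1.22 log units; beyond the scatter). Nothing available here explains the difference between the two halogens. The compounds shown leave open whether 2-iodophenyl would extend the run from chloro to bromo. They also leave open how plain phenyl or 2-methylphenyl would compare.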